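Lengthening a Carbamate Chain on a Shared Core

This account rests on a few compounds, and the source may have more. Where it says the series, first, only, none or still open, it means among the compounds named here.

Compound 2, with structure `CCCOC(=O)N1N=C(c2ccccc2)NN=C1c1ccccc1`, was tested in a functional assay on P388 cells (Mus musculus) for antiproliferative activity, read by MTT assay; a higher number here means a weaker inhibitor, a lower number a stronger inhibitor. In this assay compound 2 reaches only a limit, > 100000 nM, so no number for its potency is known. Compound 1, structure `CCOC(=O)N1N=C(c2ccccc2)NN=C1c1ccccc1`, stands one step away from compound 2 on the same core. In this assay compound 1 also returns only a limit, > 100000 nM. The step that the two limits leave unreadable from compound 1 to compound 2 therefore cannot be read, because the limit of > 100000 nM in this assay, at which 2 of the 2 values shown sit, covers both values that would define it.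

Compound 3, structure `CCCCCOC(=O)N1N=C(c2ccccc2)NN=C1c1ccccc1`, differs from compound 2 by ethyl in place of hydrogen on a saturated chain carbon, three bonds along the chain from an oxygen next to a carbonyl group. Within the data shown here, the only measured step that bears on this change is the one from compound 1 to compound 2, and its size is not readable. Nothing in the data points to a direction. The step that the limit leaves unreadable from compound 2 to compound 3 is expected to be none beyond the scatter. For compound 3 the estimate in this assay is 150000 nM, in a range from 30000 nM to 1000000 nM, most likely again reported only as a limit.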

Compound 3, half-maximal inhibitory concentration: 11800 nM
Beside the measured number, compound 3's estimate is 13-fold (1.10 log units) above it; measured number below the stated range.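

In this assay, among these compounds, this chain position is the first to give a readable change: ethyl in place of hydrogen on a saturated chain carbon, three bonds along the chain from an oxygen next to a carbonyl group, gives an at least 8.4-fold lower number from compound 2 to compound 3 (0.92 log units; beyond the scatter). Measured from the shorter chain, the change to pentyl gives an at least 8.4-fold lower number from compound 1 to compound 3 (0.92 log units; beyond the scatter), so the pentyl chain of compound 3 is the only one shown that yields a number rather than a limit. The true size of both steps remains unknown, and the step between compound 1 and compound 2 cannot be read, because both compounds sit at one limit of the assay: the limit of > 100000 nM in this assay, at which 2 of the 3 values shown sit.

A butyl chain would show where along the way from propyl to pentyl the number begins to fall, while a hexyl or octyl chain would show whether it keeps falling past pentyl. As far as these compounds go, whether a branched chain, or a pentyl chain ending in an amine or a carboxylic acid, would hold the same gain also stays open.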